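Amide nitrogen substituent series: expectation for compound 4

This account rests on a few compounds, and the source may have more. Where it says the series, first, only, none or still open, it means among the compounds named here.

Measured compounds:
compound 1 `O=C(O)C1C(C(=O)NCCCc2ccccc2)[C@H]2CC[C@@H]1O2` — 10000 nM
compound 2 `O=C(O)C1C(C(=O)Nc2ccccc2)[C@H]2CC[C@@H]1O2` — 10000 nM
compound 3 `C=CCNC(=O)C1C(C(=O)O)[C@@H]2CC[C@H]1O2` — 10000 nM

In an ADME assay on SW480 cells (Homo sapiens) for cytotoxicity, read by MTT assay, with a stated time of 72 h (a higher number here means a weaker inhibitor of growth, a lower number a stronger inhibitor of growth), compound 1 gives 10000 nM. Compound 2 gives 10000 nM in the same assay. Compound 3 gives 10000 nM, level with compounds 1 and 2 at the digits shown, so no order among the three can be read from these numbers. Among the compounds with values here, the only single-point step among them, no change at the digits printed from compound 2 to compound 3 (within the scatter), is within the scatter.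

Compound 4 `CCCCCCCCNC(=O)C1C(C(=O)O)[C@@H]2CC[C@H]1O2` is not yet measured. It differs from compound 3 in one place: heptyl in place of vinyl on a saturated chain carbon bound to an amide-type nitrogen. The change sits on the same amide nitrogen side chain that is varied across compounds 1, 2 and 3, where phenylpropyl, phenyl and allyl all gave the same reading. The step from compound 2 to compound 3 bears most directly and was flat; compound 1 versus compound 3 is likewise flat. A step beyond the scatter in this assay is therefore not expected in either direction.

The estimate for compound 4 is 10000 nM, with a range of 5000 nM to 20000 nM. This estimate means an expected step of no change at the digits printed from compound 3 to compound 4 (within the scatter), because the flat step no change at the digits printed from compound 2 to compound 3 (within the scatter) gives no sign that this nitrogen substituent moves the read-out.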

Compound 4, concentration for 50% growth inhibition: 10000 nM
The estimate for compound 4 equals the measured number at the digits printed; low and high end bracket the measured number.
By their numbers in this assay, from the lowest: compounds 1, 2, 3 and 4 (each within the scatter of the next).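

In this assay, heptyl (7 heavy atoms, no double bond) in place of vinyl (2 heavy atoms, 1 double bond) on a saturated chain carbon bound to an amide-type nitrogen gives no change at the digits printed from compound 3 to compound 4 (within the scatter), so a purely saturated, much longer chain at this position now sits alongside the allyl, phenyl and phenylpropyl groups without any shift in the read-out. Pentyl in place of phenyl on a saturated chain carbon, three bonds along the chain from an amide-type nitrogen, gives no change at the digits printed from compound 1 to compound 4 (within the scatter), so the terminal ring of compound 1 can also be exchanged for an open chain with no shift in the read-out. No measured evidence accompanies these readings to account for them.

With compounds 1, 2 and 3 level with compound 4 at 10000 nM, no link between this side chain and growth inhibition can yet be drawn. As far as these compounds go, all four compounds keep the carboxylic acid and carry only hydrocarbon groups on the amide nitrogen, so it remains open whether a terminal amine or hydroxyl on the chain, or a methyl ester in place of the carboxylic acid, would shift the reading.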